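The source may hold more compounds than are shown below. What is called first, only, known or untested is meant among the compounds shown, and "the series" means these compounds.

Measured compounds:
compound 1, `NC(=O)c1c(NC(=O)c2ccc(C(F)(F)F)cc2)sc2c1CCN(Cc1c(Cl)cccc1Cl)C2` — 8530 nM in a functional assay on MKN-74 cells (Homo sapiens) for antiproliferative activity, with a stated time of 24 h; a lower number here means a stronger inhibitor, a higher number a weaker inhibitor
compound 2, `NC(=O)c1c(NC(=O)c2ccc(C(F)(F)F)cc2)sc2c1CCN(Cc1ccc(Cl)cc1Cl)C2` — 10900 nM in this assay

On these two numbers compound 2 stands alongside compound 1: the step of a 1.3-fold higher number from compound 1 to compound 2 (0.11 log units; within the scatter) lies within the scatter, so the two cannot be told apart in this assay. Compound 3, `NC(=O)c1c(NC(=O)c2cccc([N+](=O)[O-])c2)sc2c1CCN(Cc1ccc(Cl)cc1Cl)C2`, has not yet been measured. It differs from compound 2 in one place: 3-nitrophenyl in place of 4-(trifluoromethyl)phenyl on a carbonyl carbon. Going by the values given here, no measured step touches this part of the molecule; the only step known, from compound 1 to compound 2, alters the group on the saturated chain carbon bound to the amine nitrogen in the ring and was within the scatter. With nothing to show how this assay responds to a change on the carbonyl carbon, no step beyond the scatter is expected in either direction, so for compound 3 the expected step is a 1.1-fold lower number from compound 2 to compound 3 (0.04 log units; within the scatter), with wide uncertainty. Compound 3 is therefore estimated at 10000 nM, within a range from 3000 nM to 35000 nM.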

Compound 3, half-maximal inhibitory concentration: 16500 nM
Compound 3: middle estimate off by 1.7-fold (0.22 log units), on the low side; the measured number falls inside the stated range.
By their numbers in this assay, from the lowest: compounds 1, 2 and 3 (each within the scatter of the next).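

Going by these compounds alone, this is the first view of the group on the carbonyl carbon whose other neighbour is the amide-type nitrogen, and in this assay the exchange of 4-(trifluoromethyl)phenyl for 3-nitrophenyl stays within the scatter (a 1.5-fold higher number from compound 2 to compound 3 (0.18 log units; within the scatter)). At this position, then, one substituted phenyl gave way to another, with a different substituent in a different place and with hydrogen-bond acceptors that the leaving group lacks, and the two compounds cannot be told apart. No measurement at hand bears on why this is so.

From the compounds shown here alone, it remains open whether a carboxylic acid or an amine on this phenyl, or a longer alkyl chain in its place, would carry the number beyond the scatter. Going by these compounds, it is equally open whether 3-nitrophenyl would behave the same alongside 2,6-dichlorophenyl.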